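Swapping a benzyl ether for a furoate ester on a triterpenoid

This account rests on a few compounds, and the source may have more. Where it says the series, first, only, none or still open, it means among the compounds named here.

Measured so far:
compound 1 `CC1=CC[C@H]2[C@H](CC[C@]2(C)O)C(C)(C)[C@@H]1CC[C@H]1[C@]2(C)CC[C@H](OCc3ccccc3)C(C)(C)O[C@H]2CC[C@@]1(C)O` — > 50000 nM
compound 2 `CC1=CC[C@H]2[C@H](CC[C@]2(C)O)C(C)(C)[C@@H]1CC[C@H]1[C@]2(C)CC/C(=N/O)C(C)(C)O[C@H]2CC[C@@]1(C)O` — 46800 nM

Both measured compounds share the same core and were tested in a functional assay on MCF7 cells (Homo sapiens) for antiproliferative activity, read by MTT assay, with a stated time of 72 h; on this read-out higher numbers stand for weaker inhibition and lower numbers for stronger inhibition. In this assay compound 1 gives > 50000 nM, which is a limit of the assay and not a number. In this assay compound 2 gives 46800 nM. Within the pair, compound 1 therefore stands at the limit, as one of the two values shown (the limit of > 50000 nM in this assay, at which 1 of the 2 values shown sits), and nothing more precise is known about it.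

Compound 3 `CC1=CC[C@H]2[C@H](CC[C@]2(C)O)C(C)(C)[C@@H]1CC[C@H]1[C@]2(C)CC[C@H](OC(=O)c3ccco3)C(C)(C)O[C@H]2CC[C@@]1(C)O` is not yet measured. It differs from compound 1 in one place ((furan-2-yl)carbonyl in place of benzyl on an oxygen on a saturated carbon). Among the compounds with values here, no step between measured compounds that share this change is available, so the expectation rests only on where compound 1 sits. The step from compound 1 to compound 3 in this assay is expected to be small, toward somewhat stronger inhibition if any, and may well remain within the scatter: an at least 1.2-fold lower number from compound 1 to compound 3 (0.09 log units; that floor lies within the scatter). Compound 3 is estimated at 40000 nM, with a range from 15000 nM to 100000 nM.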

Compound 3, half-maximal inhibitory concentration: 25700 nM
Compound 3: middle estimate off by 1.6-fold (0.19 log units), on the high side; the range from low to high includes it.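

In this assay, compound 1 gives > 50000 nM, which is a limit of the assay and not a number. With (furan-2-yl)carbonyl in place of benzyl on this oxygen on a saturated carbon, compound 3 gives 25700 nM, a real number, and the change reads as an at least 1.9-fold lower number from compound 1 to compound 3 (0.28 log units; that floor lies within the scatter), so this oxygen can carry an acyl group and the compound still inhibits the growth of the cells, if only weakly at these concentrations. The step can be stated only as a floor, with its true size unknown, because one end of it is not a number: the limit of > 50000 nM in this assay, at which 1 of the 3 values shown sits.

The furan ring and the carbonyl enter together in compound 3, and the compounds shown cannot tell whether either one alone accounts for the lower number, or whether the lower number goes beyond the usual scatter at all. A benzoyl group on the same oxygen would keep the carbonyl while changing the ring, and an acetyl group or a free hydroxyl there would show what happens with no ring at all.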